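The compounds below may be only part of what the source reports. "The series", "measured", "known", "first", "only" and "open" are said of these compounds alone.

Measured in a functional assay on COLO 205 cells (Homo sapiens) for inhibition, read by sulforhodamine B assay, with a stated time of 48 h, tested at 50 uM; on this read-out higher numbers stand for more inhibition of growth at the one concentration tested and lower numbers for less inhibition of growth:
- Compound 1 `COc1cccc(/C=C/C(=O)/C=C/c2ccc(OCc3cn(CCCCCOc4cc(=O)oc5ccccc45)nn3)c(OC)c2)c1`: 34%
- Compound 2 `COc1cccc(/C=C/C(=O)/C=C/c2ccc(OCc3cn(CCOc4cc(=O)oc5ccccc45)nn3)c(OC)c2)c1`: 69%
- Compound 3 `COc1cc(/C=C/C(=O)/C=C/c2cc(OC)c(OC)c(OC)c2)ccc1OCc1cn(CCOc2cc(=O)oc3ccccc23)nn1`: 86%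

Compound 3, at 86%, is the highest of these three. Compound 4 `COc1cc(/C=C/C(=O)/C=C/c2ccccc2)ccc1OCc1cn(CCOc2cc(=O)oc3ccccc23)nn1` has phenyl in place of 3,4,5-trimethoxyphenyl on a double-bonded chain carbon bound to a double-bonded chain carbon. Going by the values given here, one measured step bears on this change: a number 17 percentage points higher from compound 2 to compound 3 (beyond the scatter), with 3,4,5-trimethoxyphenyl in place of 3-methoxyphenyl at that same place. Among the compounds with values here, compound 4 carries neither group, so a fall of similar or somewhat larger size is expected in this assay, though no measured compound has the plain phenyl. The estimated change is a number 23 percentage points lower from compound 3 to compound 4 (beyond the scatter). Compound 4 is expected to give 63%, within an estimated range of 42% to 80%.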

Compound 4, percent growth inhibition at one concentration: 54%
The estimate for compound 4 lay 9 percentage points above the measured number; the measured number falls inside the stated range.
By their numbers in this assay, from the lowest: compound 1; then compound 4; then compound 2; then compound 3.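

Taking away every methoxy group from this ring costs more than the earlier step hinted (a number 32 percentage points lower from compound 3 to compound 4 (beyond the scatter)), a large fall. Losing just the single methoxy group also lowers the number (a number 15 percentage points lower from compound 2 to compound 4 (beyond the scatter)), so among these three compounds, phenyl gives the least growth inhibition, 3-methoxyphenyl more and 3,4,5-trimethoxyphenyl the most. No supporting data explain this order.

Going by these compounds, whether the gain belongs to methoxy itself remains open, since a hydroxyl, a chlorine or an amine on this ring could give a similar rise or none.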